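Swapping a nitro group for 1-(dimethylamino)ethyl

The compounds below may be only part of what the source reports. "The series", "measured", "known", "first", "only" and "open" are said of these compounds alone.

Compound 1, `CCOC(=O)c1ccc(-c2ccc(OCC)cc2)s1`: 81%
Compound 2, `CCOC(=O)c1cccc(-c2ccc([N+](=O)[O-])cc2)c1`: 63%

In an assay on COS-7 cells for inhibition of patatin-like phospholipase domain-containing protein 2 (Mus musculus), tested at 200 uM (on this read-out lower numbers stand for less inhibition and higher numbers for more inhibition at the one concentration tested (going by the name of the read-out)), compound 1 gives 81% and compound 2 gives 63%. Compound 2 thus stands lowest of the two numbers, its nearest neighbour compound 1 sitting higher by more than the usual scatter. Compound 3, `CCOC(=O)c1cccc(-c2ccc(C(C)N(C)C)cc2)c1`, differs from compound 2 in one place: 1-(dimethylamino)ethyl in place of nitro on an aromatic carbon. Among the measured compounds shown here, no measured pair shows this change, so its effect is unknown here. The step of a number 8 percentage points lower from compound 2 to compound 3 (within the scatter) is expected to be small, possibly a slight fall, and may well lie within the scatter. Compound 3 is estimated at 55%, with a range from 30% to 80%.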

Compound 3, a percentage reported as inhibition, at one concentration (the size of the read-out at that concentration, not a potency): 50%
Beside the measured number, compound 3's estimate is 5 percentage points above it, and the stated range covers the measured number.
By their numbers in this assay, from the lowest: compound 3; then compound 2; then compound 1.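

In this assay, placing 1-(dimethylamino)ethyl on this aromatic carbon in place of nitro gives a number 13 percentage points lower from compound 2 to compound 3 (beyond the scatter), the first measured effect of a change at this position. Inhibition does not vanish with this swap of 3 heavy atoms for 5, as compound 3 still gives 50% at the one concentration tested. Nothing measured here accounts for the fall. A single swap cannot separate losing nitro from gaining 1-(dimethylamino)ethyl. From the compounds shown here alone, whether a simple amine or a carboxylic acid here would land nearer compound 2 or compound 3 remains open.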